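A hydroxy group added to compound 3

The compounds below may be only part of what the source reports. "The series", "measured", "known", "first", "only" and "open" are said of these compounds alone.

Compound 1 `O=C(O)COc1ccc([C@H]2CC[C@]3(CC2)OOC2(O3)C3CC4CC2CC(C3)C4=O)cc1`: < 1.6 ug/mL, a limit
Compound 2 `O=C(O)CNC(=O)COc1ccc([C@H]2CC[C@]3(CC2)OOC2(O3)C3CC4CC(C3)CC2C4)cc1`: 12.5 ug/mL
Compound 3 `O=C(O)c1cccc([C@H]2CC[C@]3(CC2)OOC2(O3)C3CC4CC(C3)CC2C4)c1`: < 1.6 ug/mL, a limit

These values come from a physicochemical assay for solubility, read by nephelometry, in phosphate buffer, measured as kinetic solubility, with a stated time of 30 min, at pH 6.5; a higher number here means a more soluble compound, a lower number a less soluble compound. Compound 3 gives no number, only the limit < 1.6 ug/mL. Compound 1 shares that position, and the set as a whole shows (the limit of < 1.6 ug/mL in this assay, at which 2 of the 3 values shown sit). Compound 2 alone gives a number, 12.5 ug/mL.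

Compound 4 `O=C(O)c1cc([C@H]2CC[C@]3(CC2)OOC2(O3)C3CC4CC(C3)CC2C4)ccc1O` departs from compound 3 by a single change: hydroxy in place of hydrogen on an aromatic carbon. In words, it carries hydroxy in place of hydrogen on an aromatic carbon, ortho to a carboxy group and para to a large group. Among the measured compounds shown here, no measured pair carries this change, so any forecast in this assay is an expectation with little to rest on. A small upward move is expected at most, probably none beyond the scatter, and the assay may again report only a limit. The expected step is an at least 1.1-fold higher number from compound 3 to compound 4 (0.05 log units; that floor lies within the scatter). Compound 4 is estimated at 1.8 ug/mL, with an expected range of 0.8 ug/mL to 6 ug/mL.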

Compound 4, solubility: < 1.6 ug/mL
Compound 4: only a limit was reported; the forecaster's own chance of this, stated with the estimate: 60%; at least 1.1-fold (0.05 log units) between middle value and limit.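

Compound 3 and compound 4 both stand at a limit, so the step between them cannot be read: the limit of < 1.6 ug/mL in this assay, at which 3 of the 4 values shown sit.

The compounds shown leave open whether hydroxy in place of hydrogen on an aromatic carbon shifts the solubility of compound 3 in either direction.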